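Trimethoxyphenyl Replaces Methoxyphenyl on a Chalcone Scaffold

The compounds below may be only part of what the source reports. "The series", "measured", "known", "first", "only" and "open" are said of these compounds alone.

Three compounds sharing one core were tested in a functional assay on M14 cells (Homo sapiens) for inhibition; a lower number here means a stronger inhibitor of growth, a higher number a weaker inhibitor of growth. Compound 1 `COc1cc(/C=C/C(=O)c2cccc(-n3cc(-c4ccc(Cl)cc4)[nH]c3=O)c2)cc(OC)c1OC` gives 4360 nM, compound 2 `COc1cc(/C=C/C(=O)c2cccc(-n3cc(-c4ccccc4)[nH]c3=O)c2)cc(OC)c1OC` gives 1350 nM, and compound 3 `COc1ccc(-c2cn(-c3cccc(C(=O)/C=C/c4cc(OC)c(OC)c(OC)c4)c3)c(=O)[nH]2)cc1` gives 1850 nM. The step of a 3.2-fold lower number from compound 1 to compound 2 (0.51 log units; beyond the scatter) and the step of a 2.4-fold lower number from compound 1 to compound 3 (0.37 log units; beyond the scatter) were both modest, while the step of a 1.4-fold higher number from compound 2 to compound 3 (0.14 log units; within the scatter) stayed within the scatter. Compound 3 thus stands second highest of the three numbers: its nearest neighbour is compound 2, within the scatter, and its furthest is compound 1, beyond it.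

Compound 4 `COc1cc(/C=C/C(=O)c2cccc(-n3cc(-c4cc(OC)c(OC)c(OC)c4)[nH]c3=O)c2)cc(OC)c1OC` differs from compound 3 by 3,4,5-trimethoxyphenyl in place of 4-methoxyphenyl on an aromatic carbon, on an aromatic carbon of a five-membered aromatic ring with 2 nitrogen, next to the ring nitrogen. For the measured compounds named here, the only measured steps that bear on this change are those varying the same aromatic carbon, and the largest of them, from compound 1 to compound 2, was only modest, while the step from compound 2 to compound 3 did not rise above the scatter. Compound 4 is therefore expected to show a step of a 1.1-fold higher number from compound 3 to compound 4 (0.03 log units; within the scatter) that lies within the scatter, with no clear direction. The estimate for compound 4 in this assay is 2000 nM, with a range from 800 nM to 5000 nM.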

Compound 4, concentration for 50% growth inhibition: 2120 nM
Beside the measured number, compound 4's estimate is 1.1-fold (0.03 log units) below it, within the range that was stated.
By their numbers in this assay, from the lowest: compounds 2, 3 and 4 (each within the scatter of the next); then compound 1.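

In this assay, this aromatic carbon of the five-membered aromatic ring takes 3,4,5-trimethoxyphenyl, with 12 heavy atoms against 8 in 4-methoxyphenyl, without a step beyond the scatter (a 1.1-fold higher number from compound 3 to compound 4 (0.06 log units; within the scatter)). The comparison with the unsubstituted phenyl also stays within the scatter (a 1.6-fold higher number from compound 2 to compound 4 (0.20 log units; within the scatter)), so compounds 2, 3 and 4 form one group in this read-out, while the 4-chlorophenyl of compound 1 remains apart, by a modest step (a 2.1-fold lower number from compound 1 to compound 4 (0.31 log units; beyond the scatter)). No measurement is available that explains why the three rings cannot be told apart or why compound 1 stands apart.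

As far as these compounds go, whether this position would accept something other than a substituted phenyl, such as an amine, a carboxylic acid or a longer alkyl chain, remains open. From the compounds shown here alone, it is also open whether the separation of compound 1 is particular to chloro or would be shared by fluoro or bromo on the same ring, and whether the grouping of compounds 2, 3 and 4 would hold in other cell lines.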